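The source may hold more compounds than are shown below. What is called first, only, known or untested is meant among the compounds shown, and "the series" means these compounds.

Measured so far:
- compound 1 `CC(=O)c1ccc(OCCCN2CC[C@H](NC(=O)c3ccc(C#N)cc3)C2)cc1`: 6100 nM
- compound 2 `O=C(c1ccc(OCCCN2CC[C@H](NS(=O)(=O)c3cccc(F)c3)C2)cc1)C1CC1`: 1600 nM
- compound 3 `CC(=O)c1ccc(OCCCN2CC[C@H](NS(=O)(=O)c3ccc(C#N)cc3)C2)cc1`: 2300 nM

In an assay on isolated protein for binding affinity to histamine H2 receptor (Homo sapiens) (a higher number here means a weaker inhibitor, a lower number a stronger inhibitor), compound 2 stands at the lowest of the three numbers. Its gap to compound 3 lies within the scatter, so the two cannot be ranked; its gap to compound 1 lies beyond the scatter.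

Compound 4 `O=C(c1ccc(OCCCN2CC[C@H](NS(=O)(=O)c3ccc(F)cc3)C2)cc1)C1CC1` is the next compound of the series. It differs from compound 2 in one place: 4-fluorophenyl in place of 3-fluorophenyl on a sulfonyl sulfur. Among the compounds with values here, no measured pair of the series shows this change, so there is no step to draw on. The expectation is a step of no size beyond the scatter, estimated as a 1.1-fold higher number from compound 2 to compound 4 (0.05 log units; within the scatter). For compound 4 in this assay the estimate is 1800 nM, with a range from 700 nM to 4500 nM.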

Compound 4, inhibition constant: 500 nM
Estimate against measurement, compound 4: 3.6-fold (0.56 log units) above; the whole stated range lies above it.
By their numbers in this assay, from the lowest: compound 4; then compounds 2 and 3 (each within the scatter of the next); then compound 1.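

In this assay 4-fluorophenyl in place of 3-fluorophenyl on a sulfonyl sulfur gives a 3.2-fold lower number from compound 2 to compound 4 (0.51 log units; beyond the scatter) with the same atoms, joined differently. Within the data shown here, this is the first one-place pair of the series, and it shows that the number at this position follows where the fluorine sits on the phenyl ring, not only that fluorine is present. Nothing measured here accounts for the step.

Still open, from the compounds shown here alone, is how a 4-fluorophenyl compares with an unsubstituted phenyl or a chlorophenyl on the same sulfur. Also open, going by these compounds, is whether the step carries over to compounds with an acetyl group in place of the cyclopropyl ketone.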